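The compounds below may be only part of what the source reports. "The series", "measured", "known", "first", "only" and "open" are said of these compounds alone.

Three compounds built on one shared core have so far been examined in an ADME assay on cells (Peritoneal macrophage, Mus musculus, strain Balb/c) for cytotoxicity, read by resazurin assay, with a stated time of 72 h; a higher number here means that more compound is tolerated, a lower number that less compound is tolerated. In this assay compound 1 `CC1(Cc2ccccc2)CC(S(=O)(=O)c2ccc(F)cc2)=C(c2ccc(/C(N)=N/O)cc2)O1` gives 102000 nM. Compound 2 `CC1(Cc2ccc(C(F)(F)F)cc2)CC(S(=O)(=O)c2ccc(F)cc2)=C(c2ccc(/C(N)=N/O)cc2)O1` gives 103000 nM, and compound 3 `CC1(Cc2ccc([N+](=O)[O-])cc2)CC(S(=O)(=O)c2ccc(F)cc2)=C(c2ccc(/C(N)=N/O)cc2)O1` gives 97400 nM. Compound 2 holds the highest of the three numbers, yet its steps to the others, a 1.0-fold higher number from compound 1 to compound 2 (0.00 log units; within the scatter) and a 1.1-fold lower number from compound 2 to compound 3 (0.02 log units; within the scatter), both lie within the scatter, as does a 1.0-fold lower number from compound 1 to compound 3 (0.02 log units; within the scatter). Compound 4 `CC1(Cc2ccccc2Br)CC(S(=O)(=O)c2ccc(F)cc2)=C(c2ccc(/C(N)=N/O)cc2)O1` has not yet been measured. It differs from compound 2 in one place: 2-bromophenyl in place of 4-(trifluoromethyl)phenyl on a saturated chain carbon bound to a saturated ring carbon. Within the data shown here, the steps that bear on this change are the three already named, each of which swaps a substituent on an aromatic carbon in the same part of the molecule and each of which stayed within the scatter in this assay. On that basis no step beyond the scatter is expected from compound 2 to compound 4, and the estimated step of a 1.0-fold lower number from compound 2 to compound 4 (0.01 log units; within the scatter) reflects this. Compound 4 is therefore expected to give about 100000 nM in this assay, within a range from 55000 nM to 180000 nM.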

Compound 4, half-maximal cytotoxic concentration: 109000 nM
Beside the measured number, compound 4's estimate is 1.1-fold (0.04 log units) below it, and the stated range covers the measured number.
By their numbers in this assay, from the lowest: compounds 3, 1, 2 and 4 (each within the scatter of the next).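

Until now the steps in this assay had only exchanged hydrogen, trifluoromethyl and nitro on an aromatic carbon, and bromo brings no step beyond the scatter either, with a 1.1-fold higher number from compound 1 to compound 4 (0.03 log units; within the scatter) and a 1.1-fold higher number from compound 2 to compound 4 (0.02 log units; within the scatter) and also a 1.1-fold higher number from compound 3 to compound 4 (0.05 log units; within the scatter) as the three readings. 2-Bromophenyl in place of 4-(trifluoromethyl)phenyl or 4-nitrophenyl, on a saturated chain carbon bound to a saturated ring carbon, therefore extends the run of changes at this position that stay within the scatter. Nothing at hand speaks to why these four numbers stay together.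

The compounds shown leave open whether an amine or a carboxylic acid on this aromatic ring would also stay within the scatter. Also open, as far as these compounds go, is whether a longer chain in place of the benzyl group would do so.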